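The source may hold more compounds than are shown below. What is called first, only, known or untested is meant among the compounds shown, and "the series" means these compounds.

Measured in an ADME assay on PC-3 cells (Homo sapiens) for cytotoxicity, read by sulforhodamine B assay, with a stated time of 48 h, tested at 10 uM; on this read-out lower numbers stand for less inhibition and higher numbers for more inhibition at the one concentration tested (going by the name of the read-out):

Compound 1, `CCCCCCCc1cn(C(c2ccccc2)c2cc3cc(Br)ccc3nc2OC)nn1`: 4.42%
Compound 2, `COc1nc2ccc(Br)cc2cc1C(c1ccccc1)n1cc(-c2ccccc2)nn1`: 5.97%

Both compounds share the same core and differ only in the group carried on the five-membered aromatic ring. Compound 2 gives 5.97% in this assay, and the step of a number 1.6 percentage points higher from compound 1 to compound 2 (within the scatter) is too small to tell the two numbers apart; compound 2 therefore stands at a level indistinguishable from compound 1.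

Compound 3, `CCCCCCCCc1cn(C(c2ccccc2)c2cc3cc(Br)ccc3nc2OC)nn1`, is not yet measured. It differs from compound 2 by octyl in place of phenyl on an aromatic carbon. Going by the values given here, this change runs opposite to the one measured step, which swapped a heptyl chain for phenyl and moved the read-out by only a number 1.6 percentage points higher from compound 1 to compound 2 (within the scatter). The octyl chain in compound 3 is one carbon longer than that heptyl chain. On the evidence of that single step, no movement beyond the usual scatter is expected for compound 3; the estimated step is a number 1 percentage points lower from compound 2 to compound 3 (within the scatter). Compound 3 is expected to give about 5% in this assay, within a range of 0% to 15%.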

Compound 3, a percentage reported as inhibition, at one concentration (the size of the read-out at that concentration, not a potency): 2.27%
Beside the measured number, compound 3's estimate is 2.7 percentage points above it; the measured number falls inside the stated range.
By their numbers in this assay, from the lowest: compounds 3, 1 and 2 (each within the scatter of the next).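

Swapping phenyl for octyl, a chain with no ring, on this aromatic carbon of the five-membered ring gives a number 3.7 percentage points lower from compound 2 to compound 3 (within the scatter) in this assay. Adding one carbon to the chain, seen as methyl in place of hydrogen seven bonds along the chain from an aromatic carbon, gives a number 2.2 percentage points lower from compound 1 to compound 3 (within the scatter). So this read-out does not separate heptyl, octyl and phenyl at this position, whether the group is a saturated chain or an aromatic ring. No supporting measurement bears on these numbers.

The compounds shown leave open whether a group carrying an amine or a carboxylic acid at this position would give a step beyond the scatter. They also leave open what a short chain such as methyl would give here.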